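Permeability Notes: From Compound 2 to Compound 4

This account rests on a few compounds, and the source may have more. Where it says the series, first, only, none or still open, it means among the compounds named here.

Measured so far:
compound 1 `COC(C)(C)[C@@H](O)C(=O)N1N=CC[C@H]1C(=O)NCc1cc(Cl)ccc1-n1cnnn1`: 1.7 10^-6 cm/s
compound 2 `O=C(O[C@@H](C(=O)N1N=CC[C@H]1C(=O)NCc1cc(Cl)ccc1-n1cnnn1)c1ccc(F)cc1)c1ccccc1`: 43 10^-6 cm/s
compound 3 `O=C(NCc1cc(Cl)ccc1-n1cnnn1)[C@@H]1[C@H]2C[C@H]2CN1C(=O)[C@H](O)Cn1cccn1`: 0.31 10^-6 cm/s

In an ADME assay on Caco-2 cells (Homo sapiens) for permeability, read by LC-MS, in the apical to basolateral direction, with a stated time of 60 min, at pH 6.5 (on this read-out higher numbers stand for higher permeability and lower numbers for lower permeability), compound 2 stands highest of the three numbers; compound 1 and compound 3 both lie far below it, each gap beyond the scatter. Compound 4 `CCCC(=O)O[C@@H](C(=O)N1N=CC[C@H]1C(=O)NCc1cc(Cl)ccc1-n1cnnn1)c1ccc(F)cc1` has not been measured. It differs from compound 2 in one place: propyl in place of phenyl on a carbonyl carbon. Among the compounds with values here, no step between two measured compounds matches this change, so the expectation rests on the shared ester type of compound 2 and compound 4, with no donor or acceptor gained or lost. The step from compound 2 to compound 4 is expected to be small, within the scatter, with no set direction. The estimate for compound 4 is 30 10^-6 cm/s, with a range from 12 10^-6 cm/s to 70 10^-6 cm/s, and an expected step of a 1.4-fold lower number from compound 2 to compound 4 (0.16 log units; within the scatter).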

Compound 4, apparent permeability: 25 10^-6 cm/s
Compound 4: middle estimate off by 1.2-fold (0.08 log units), on the high side, within the range that was stated.
By their numbers in this assay, from the lowest: compound 3; then compound 1; then compounds 4 and 2 (each within the scatter of the next).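

In this assay, propyl in place of phenyl on a carbonyl carbon gives a 1.7-fold lower number from compound 2 to compound 4 (0.24 log units; within the scatter), so at this place an open chain and a six-membered aromatic ring read alike within the scatter. Within the data shown here, this is the first step that changes one place only, and the earlier compounds offered no such comparison. No measurement at hand accounts for the result. The compounds shown leave open how a longer chain, a branched chain or an amine would read on this carbonyl carbon.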